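The source may hold more compounds than are shown below. What is called first, only, known or untested is meant among the compounds shown, and "the series" means these compounds.

In a functional assay on A549 cells (Homo sapiens) for cytotoxicity, read by MTT assay, with a stated time of 72 h (on this read-out higher numbers stand for weaker inhibition and lower numbers for stronger inhibition), compound 3 `COc1ccccc1/C=C1\CCC/C(=C\c2ccc(OC)c(OC)c2)C1=O` gives no number, only a limit of the assay: > 20000 nM. Two close relatives do give numbers: compound 1 `COc1ccc(/C=C2\CCC/C(=C\c3cccc(Cl)c3)C2=O)cc1OC` reads 11000 nM and compound 2 `COc1ccc(/C=C2\CCC/C(=C\c3cccc(Br)c3)C2=O)cc1OC` reads 12800 nM. Swapping between those two halogens changes little: a 1.2-fold higher number from compound 1 to compound 2 (0.07 log units; within the scatter).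

The next compound, compound 4 `COc1ccc(/C=C2\CCC/C(=C\c3ccc(Cl)cc3Cl)C2=O)cc1OC`, differs from compound 3 as follows: 2,4-dichlorophenyl in place of 2-methoxyphenyl on a double-bonded chain carbon bound to a double-bonded ring carbon. The most relevant evidence comes from two steps that also involve 2-methoxyphenyl, which replaces 3-chlorophenyl in an at least 1.8-fold higher number from compound 1 to compound 3 (0.25 log units; that floor lies within the scatter) and 3-bromophenyl in an at least 1.5-fold higher number from compound 2 to compound 3 (0.19 log units; that floor lies within the scatter). Both are only floors, so the true gaps may be larger. The move to 2,4-dichlorophenyl runs the opposite way, so a lower number, meaning stronger inhibition, is expected in this assay. Going by the values given here, no compound with this exact ring has been measured, so the expected shift is modest and uncertain.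

The estimated change is an at least 2.0-fold lower number from compound 3 to compound 4 (0.30 log units; that floor lies within the scatter).

For compound 4 the estimate is 10000 nM, with an expected range from 4500 nM to 20000 nM.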

Compound 4, half-maximal inhibitory concentration: > 20000 nM
Compound 4 ended at the assay's limit; the forecaster's own chance of this, stated with the estimate: 15%; at least 2.0-fold (0.30 log units) between middle value and limit.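

At this place, on a double-bonded chain carbon bound to a double-bonded ring carbon, a halogen-bearing ring does not ensure a readable value in this assay: 2,4-dichlorophenyl ends at a limit of the assay, as 2-methoxyphenyl does, while 3-chlorophenyl and 3-bromophenyl gave numbers. Against those two rings, the steps are an at least 1.8-fold higher number from compound 1 to compound 4 (0.25 log units; that floor lies within the scatter) and an at least 1.5-fold higher number from compound 2 to compound 4 (0.19 log units; that floor lies within the scatter), and as floors they do not fix the true gaps. The step between compound 3 and compound 4 cannot be read, because both stand at the same limit: the limit of > 20000 nM in this assay, at which 2 of the 4 values shown sit.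

Which of these two rings gives the weaker inhibition therefore stays open. Also open, going by these compounds, is how a phenyl ring carrying an amine or a carboxylic acid would read at this place.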